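Swapping thiophene for phenyl on the chain of compound 3

The source may hold more compounds than are shown below. What is called first, only, known or untested is meant among the compounds shown, and "the series" means these compounds.

Measured so far:
- Compound 1, `FC(F)(F)CCCSc1nsnc1[C@@H]1CN2CCC[C@@H]1C2`: 0.35 mg/kg
- Compound 2, `CCCCCCSc1nccnc1C1CN2CCC1CC2`: 2.3 mg/kg
- Compound 3, `CN1CCC=C(c2nsnc2SCCCc2cccs2)C1`: > 10 mg/kg

The read-out throughout is a functional assay on the whole organism with Mus musculus as the target, in the writhing test; on this read-out higher numbers stand for an effect only at larger amounts of compound and lower numbers for an effect already at smaller amounts. Compound 1 and compound 2 both give a numerical dose in this assay, compound 1 at 0.35 mg/kg and compound 2 at 2.3 mg/kg. Compound 3 is different: in this assay it reaches only a limit of the test, > 10 mg/kg, so no number is known for it, only that the effect was not seen within the range tried (the limit of > 10 mg/kg in this assay, at which 1 of the 3 values shown sits). Among the three values shown, compound 3 therefore stands at the weak end, with no measured step linking it to compound 1 or compound 2.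

Compound 4, `CN1CCC=C(c2nsnc2SCCCc2ccccc2)C1`, has not yet been tested. It differs from compound 3 in one spot: phenyl in place of thiophen-2-yl on a saturated chain carbon, three bonds along the chain from a sulfur. Among the compounds with values here, since compound 3 is known only as a limit, no measured step shows what such a swap does here, and the change is small in the count of atoms. The step from compound 3 to compound 4, a step that the limit leaves unreadable from compound 3 to compound 4, is expected to be none beyond the usual scatter. Compound 4 is therefore expected to sit near 12 mg/kg, somewhere between 4 mg/kg and 40 mg/kg, with a fair chance that this assay again reports only a limit.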

Compound 4, dose for half-maximal effect: > 10 mg/kg
Compound 4: only a limit was reported; the forecaster's own chance of this, stated with the estimate: 60%; the middle value does not contradict the limit.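

Within the data shown here, neither compound 3 nor compound 4 gives a number in this assay, so the swap of thiophen-2-yl for phenyl yields no step that can be read: the limit of > 10 mg/kg in this assay, at which 2 of the 4 values shown sit. The compounds shown leave open how far apart compound 3 and compound 4 truly lie, and what dose of either would give the half-maximal effect.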